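The source may hold more compounds than are shown below. What is called first, only, known or untested is meant among the compounds shown, and "the series" means these compounds.

Compound 1 `CC(C)C[C@H](NC(=O)c1cc(Cl)ccc1OCCNC(=O)OC(C)(C)C)C(=O)Nc1ccc([N+](=O)[O-])cc1Cl` and compound 2 `CC(C)C[C@H](NC(=O)c1cc(Cl)ccc1OCCN)C(=O)Nc1ccc([N+](=O)[O-])cc1Cl` rest on one core, while compound 3 `CC(C)(C)OC(=O)NCCOc1ccc(Cl)cc1C(=O)NCC(=O)Nc1ccc2c(c1)S(=O)(=O)C=C2` and compound 4 `NCCOc1ccc(Cl)cc1C(=O)NCC(=O)Nc1ccc2c(c1)S(=O)(=O)C=C2` rest on another; the difference between the two cores is not broken down here. In a functional assay on MCF7 cells (Homo sapiens) for inhibition, read by MTT assay, with a stated time of 72 h (a higher number here means a weaker inhibitor, a lower number a stronger inhibitor), compound 1 gives only a limit, > 10000 nM. Compound 2 likewise gives only a limit in this assay, > 10000 nM. The change from compound 1 to compound 2 is hydrogen in place of tert-butoxycarbonyl on an amine nitrogen, and its size stays hidden: a step that the two limits leave unreadable from compound 1 to compound 2, which follows from the limit of > 10000 nM in this assay, at which 2 of the 3 values shown sit. Among the compounds with values here, compound 3 supplies the one real number of the set, 1430 nM in this assay. Compound 4 carries the same change, (hydrogen in place of tert-butoxycarbonyl on an amine nitrogen), on the core of compound 3, with the same surroundings at the place of change. Within the data shown here, because a step that the two limits leave unreadable from compound 1 to compound 2 gives no size, there is no measured step to carry across to the second core. The expected step is set close to no change, a 1.7-fold higher number from compound 3 to compound 4 (0.24 log units; within the scatter), with wide uncertainty on either side. Compound 4 is accordingly estimated at 2500 nM in this assay, with a plausible range from 500 nM to 10000 nM.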

Compound 4, half-maximal inhibitory concentration: 9440 nM
Compound 4: the middle estimate sits 3.8-fold (0.58 log units) below what was measured; measured number inside the range.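

On the core of compound 3, hydrogen in place of tert-butoxycarbonyl on an amine nitrogen appears in this assay as a 6.6-fold higher number from compound 3 to compound 4 (0.82 log units; beyond the scatter), a modest but readable loss of inhibition that rests on this single pair. This shows that the change can register on this core, but it does not show that the step has the same size or direction on the core of compound 1, since compound 1 and compound 2 both give only limits and their step cannot be read. Within the data shown here, no comparison of the step between the two cores is therefore possible, and the one pair that could supply it stays unreadable because both of its compounds sit at the limit: the limit of > 10000 nM in this assay, at which 2 of the 4 values shown sit.

The compounds shown leave open whether an acetyl group or a methyl carbamate on the amine nitrogen would give a value nearer that of compound 3 or that of compound 4. They also leave open how a carboxylic acid in place of the amine, or a chain longer than 2-aminoethyl, would read on either core.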